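Aryl hydrazone series: expectation for a dimethoxyphenyl analogue

A few compounds are considered here, and "the series" means these few. Any claim that something is new, unique, unknown or untested is made for them only; others in the source may bear on it.

Measured so far:
- compound 1 `Cc1cccc(/C=N/Nc2ncc3c(n2)n(C2CCCC2)c(=O)c(=O)n3C)c1`; in a functional assay on A549 cells (Homo sapiens) for antiproliferative activity, read by MTT assay (a lower number here means a stronger inhibitor, a higher number a weaker inhibitor), compound 1 gives 34500 nM
- compound 2 `Cn1c(=O)c(=O)n(C2CCCC2)c2nc(N/N=C/c3ccc(Cl)cc3)ncc21`; in this assay compound 2 gives 6890 nM

For the measured compounds named here, compound 2 holds the lower of the two numbers; the only step measured is a 5.0-fold lower number from compound 1 to compound 2 (0.70 log units; beyond the scatter). Compound 3 `COc1ccc(/C=N/Nc2ncc3c(n2)n(C2CCCC2)c(=O)c(=O)n3C)c(OC)c1` is not yet measured. It differs from compound 2 in one place: 2,4-dimethoxyphenyl in place of 4-chlorophenyl on a carbon with a double bond to nitrogen. Going by the values given here, the single known step bears on this change only loosely, since it swapped one aryl group for another at the same carbon; no step involving a methoxy group exists. The expected step is a 1.7-fold higher number from compound 2 to compound 3 (0.24 log units; within the scatter), with wide uncertainty. Compound 3 is therefore estimated at 12000 nM, within 3000 nM to 50000 nM.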

Compound 3, half-maximal inhibitory concentration: > 100000 nM
Compound 3 ended at the assay's limit; the forecaster's own chance of this, stated with the estimate: 10%; middle value at least 8.3-fold (0.92 log units) away from the limit.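

For the compounds shown here, on a carbon with a double bond to nitrogen, the aryl group can matter more than the single earlier step showed: 2,4-dimethoxyphenyl in place of 4-chlorophenyl gives an at least 14-fold higher number from compound 2 to compound 3 (1.16 log units; beyond the scatter). The same group also compares unfavourably with 3-methylphenyl, giving an at least 2.8-fold higher number from compound 1 to compound 3 (0.46 log units; beyond the scatter), so the loss appears against both aryl groups shown. Compound 3 stands at a limit of this assay, not at a number: the limit of > 100000 nM in this assay, at which 1 of the 3 values shown sits.

Open, from the compounds shown here alone, is whether one methoxy group alone would repeat this loss. Also open, going by these compounds, is where an amine or a carboxylic acid on the aryl group would fall in this assay.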